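A few compounds are considered here, and "the series" means these few. Any claim that something is new, unique, unknown or untested is made for them only; others in the source may bear on it.

Compound 1 `O=C(/C=C/c1ccc(O)c(O)c1)c1ccc(O)cc1` is the reference point of this small set. In an assay on RBL-1 cells for inhibition of Polyunsaturated fatty acid 5-lipoxygenase (Rattus norvegicus) (a lower number here means a stronger inhibitor, a higher number a weaker inhibitor), compound 1 gives 4 nM. Compound 2 `Cc1ccc(C(=O)/C=C/c2ccc(O)c(O)c2)cc1` carries the change (methyl in place of hydroxy on an aromatic carbon), and in this assay compound 2 gives 76 nM; the step of a 19-fold higher number from compound 1 to compound 2 (1.28 log units; beyond the scatter) is large. Compound 3 `O=C(/C=C/c1ccc(O)c(O)c1)c1cc(O)ccc1O` rests on a different core, and the difference between the two cores is not broken down here. In this assay compound 3 gives 64 nM, which sits close to compound 2 and far from compound 1.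

Compound 4 `Cc1ccc(O)c(C(=O)/C=C/c2ccc(O)c(O)c2)c1` has not been measured. It differs from compound 3 by methyl in place of hydroxy on an aromatic carbon. Within the data shown here, this is the same kind of change as the one from compound 1 to compound 2, but the surroundings differ: in compound 2 the methyl stands para to a large group, whereas in compound 4 it stands meta to a large group and para to a hydroxy group. Among the measured compounds shown here, because the only measured instance, a 19-fold higher number from compound 1 to compound 2 (1.28 log units; beyond the scatter), was large, the step from compound 3 to compound 4 is expected to be of similar size, a 14-fold higher number from compound 3 to compound 4 (1.15 log units; beyond the scatter), with added uncertainty from the different place. Compound 4 is therefore estimated at 900 nM in this assay, between 200 nM and 4000 nM.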

Compound 4, half-maximal inhibitory concentration: 39 nM
Beside the measured number, compound 4's estimate is 23-fold (1.36 log units) above it; the whole stated range lies above it.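

In this assay, the effect of methyl in place of hydroxy did not carry from one core to the other: the same change on two cores in this assay, a 19-fold higher number (1.28 log units; beyond the scatter) from compound 1 to compound 2 and a 1.6-fold lower number (0.22 log units; within the scatter) from compound 3 to compound 4, 31-fold (1.49 log units) apart, beyond the scatter of two such steps The new step, a 1.6-fold lower number from compound 3 to compound 4 (0.22 log units; within the scatter), means that on the core of compound 3 the change leaves the reading unmoved within the scatter, so the large step seen on the core of compound 1 cannot be taken as a general result of this change. Among these compounds, with only two pairs, however, this does not show whether the difference follows the place of the change on the ring, the further hydroxy group present in compound 4, or something else in the two cores.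

The compounds shown leave open whether an amine, a methoxy group or a fluorine at these same places would follow the large step or the small one. They also leave open how changes on the other aromatic ring, which stays the same in all four compounds, would read in this assay.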